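A few compounds are considered here, and "the series" means these few. Any claim that something is new, unique, unknown or untested is made for them only; others in the source may bear on it.

Measured so far:
compound 1, `COc1cc(-c2nn(-c3cccc(NC(=O)Nc4cc(C(F)(F)F)cc(C(F)(F)F)c4)c3)cc2-c2ccncc2)ccc1Cl` — 2670 nM
compound 2, `COc1cc(-c2nn(-c3cccc(NC(=O)Nc4ccc(Cl)c(Cl)c4)c3)cc2-c2ccncc2)ccc1Cl` — 3020 nM

Both compounds were tested in a functional assay on SK-MEL-5 cells (Homo sapiens) for inhibition, read by sulforhodamine B assay, with a stated time of 48 h; a lower number here means that less compound is tolerated, a higher number that more compound is tolerated. In this assay compound 1 gives 2670 nM and compound 2 gives 3020 nM. The two numbers lie within the usual scatter of each other, so compound 1 and compound 2 cannot be told apart on this assay, and compound 1 simply serves as the reference point for the next step.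

The unmeasured compound 3, `COc1cc(-c2nn(-c3cccc(NC(=O)Nc4cccc(C(F)(F)F)c4)c3)cc2-c2ccncc2)ccc1Cl`, is reached from compound 1 by a single change: hydrogen in place of trifluoromethyl on an aromatic carbon of the aryl urea. Among the compounds with values here, no pair of measured compounds shows this particular step, so its size has to be guessed. Removing one of the two trifluoromethyl groups is expected to make the cells tolerate somewhat more compound, a modest rise in the number rather than none at all, though a result within the scatter would not be surprising.

Compound 3 is therefore expected to give about 4200 nM, within a range from 1600 nM to 11000 nM. The estimated step of a 1.6-fold higher number from compound 1 to compound 3 (0.20 log units; within the scatter) expresses this expectation.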

Compound 3, concentration lethal to 50% of the cells: 2680 nM
Estimate against measurement, compound 3: 1.6-fold (0.20 log units) above; the range from low to high includes it.
By their numbers in this assay, from the lowest: compounds 1, 3 and 2 (each within the scatter of the next).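

In this assay, hydrogen in place of trifluoromethyl on an aromatic carbon of the aryl urea gives a 1.0-fold higher number from compound 1 to compound 3 (0.00 log units; within the scatter), so at this place, meta to a trifluoromethyl group, the assay does not tell the two groups apart even though four heavy atoms leave. The step to 3-(trifluoromethyl)phenyl in place of 3,4-dichlorophenyl on an amide-type nitrogen gives a 1.1-fold lower number from compound 2 to compound 3 (0.05 log units; within the scatter), which leaves all three compounds, taken in order of their numbers, each within the scatter of the next. Nothing measured here accounts for this insensitivity to the change.

The compounds shown leave open whether the remaining trifluoromethyl group on this ring can also give way to hydrogen with as little effect on the number. They also do not show whether a quite different group at this place, such as a carboxylic acid or an amine, would stay within the scatter of compound 3 or move the number clearly beyond it.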